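The compounds below may be only part of what the source reports. "The series", "measured", "known", "first", "only" and "open" are said of these compounds alone.

Working notes on the series.

The shared core carries a substituted aminomethyl group on its ring nitrogen-bearing position, and three variants of that group have been measured in an assay on COS-7 cells for inhibition of sodium/nucleoside cotransporter 2 (Homo sapiens), read by scintillation counting, in the presence of a further agent that is not named here; a higher number here means a weaker inhibitor, a lower number a stronger inhibitor. Compound 2 `Cc1cccc(CNc2nc3c(N)ncnc3n2[C@@H]2O[C@H](CO)[C@@H](O)[C@H]2O)c1` gives 19000 nM in this assay. Compound 3 `Nc1ncnc2c1nc(NCCCc1ccccc1)n2[C@@H]1O[C@H](CO)[C@@H](O)[C@H]1O` gives 536000 nM in this assay, and the step of a 28-fold higher number from compound 2 to compound 3 (1.45 log units; beyond the scatter) is large. Compound 1 `COc1ccccc1CNc1nc2c(N)ncnc2n1[C@@H]1O[C@H](CO)[C@@H](O)[C@H]1O` reaches only the limit of the assay at > 100000 nM, which is a limit and not a number; this is the limit of > 100000 nM in this assay, at which 1 of the 3 values shown sits. Among the two numbers that are not limits, compound 2 stands lowest, with compound 3 as its nearest value and the step of an at least 5.2-fold lower number from compound 1 to compound 2 (0.72 log units; beyond the scatter) running from a limit.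

Compound 4 `Nc1ncnc2c1nc(NCc1cccc(-c3ccccc3)c1)n2[C@@H]1O[C@H](CO)[C@@H](O)[C@H]1O` differs from compound 2 by phenyl in place of methyl on an aromatic carbon, the replacement being phenyl in place of methyl on an aromatic carbon. Every measured step in this assay changes the group on the saturated chain carbon bound to a nitrogen on an aromatic ring, while the change to compound 4 sits on the aromatic ring itself; none of them therefore bears directly on it, and no reading of direction or size can be taken from them. With nothing pointing either way, a step within the scatter is expected, that is a 1.3-fold lower number from compound 2 to compound 4 (0.10 log units; within the scatter), and compound 4 is estimated at 15000 nM in this assay, with a range of 4000 nM to 60000 nM.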

Compound 4, half-maximal inhibitory concentration: 21000 nM
Compound 4: the middle estimate sits 1.4-fold (0.15 log units) below what was measured, within the range that was stated.
By their numbers in this assay, from the lowest: compounds 2 and 4 (each within the scatter of the next); then compound 3.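

On the aromatic ring, phenyl in place of methyl gives a 1.1-fold higher number from compound 2 to compound 4 (0.04 log units; within the scatter), the only step shown at this aromatic carbon, and in this assay it leaves compound 2 and compound 4 inside the scatter of each other. At this place, meta to a large group, a phenyl of 6 heavy atoms with one six-membered aromatic ring therefore stands where a methyl of 1 heavy atom stood, with no readable difference in the number, whereas a change to the group on the saturated chain carbon gives a 28-fold higher number from compound 2 to compound 3 (1.45 log units; beyond the scatter), which is beyond the scatter. Nothing in the evidence available bears on why this larger replacement leaves the number inside the scatter.

With only methyl and phenyl shown at this aromatic carbon, it remains open whether an amine, a carboxylic acid or a longer chain there would also stay within the scatter of compound 2 or would move the number beyond it. As far as these compounds go, it also remains open whether a second aromatic ring carrying a methoxy group or a fluorine would read the same as the unsubstituted phenyl of compound 4.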